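Meta Substituent Swap on the Phenyl Ring: Methyl to Cyano

The compounds below may be only part of what the source reports. "The series", "measured", "known", "first", "only" and "open" are said of these compounds alone.

Measured compounds:
compound 1 `Cc1cc(NC(=O)Cn2nnc(-c3cccc(Cl)c3)n2)n(C2CCCCC2)n1` — 300 nM
compound 2 `Cc1ccc(-c2nnn(CC(=O)Nc3cc(C)nn3C3CCCCC3)n2)cc1` — 111 nM
compound 3 `Cc1cccc(-c2nnn(CC(=O)Nc3cc(C)nn3C3CCCCC3)n2)c1` — 129 nM

Of the compounds shown here, three sharing one core have been measured in an assay on HEK293 cells for activation of Kir3.1/Kir3.2 (Homo sapiens), read by thallium flux; a higher number here means that more compound is needed for the effect, a lower number that less compound is needed. Compound 1 gives 300 nM in this assay, compound 2 gives 111 nM, and compound 3 gives 129 nM. Compound 3 stands second highest of the three numbers: its nearest neighbour is compound 2, a step that lies within the scatter (a 1.2-fold higher number from compound 2 to compound 3 (0.07 log units; within the scatter)), and its furthest is compound 1 (a 2.3-fold lower number from compound 1 to compound 3 (0.37 log units; beyond the scatter)).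

Compound 4 `Cc1cc(NC(=O)Cn2nnc(-c3cccc(C#N)c3)n2)n(C2CCCCC2)n1` has not yet been measured. It differs from compound 3 in one place: cyano in place of methyl on an aromatic carbon.

Going by the values given here, the only measured step at the same position is the exchange of chloro for methyl, a 2.3-fold lower number from compound 1 to compound 3 (0.37 log units; beyond the scatter), which gave a modest lowering of the number. Among the compounds with values here, no step with cyano has been measured, so the direction of the new change cannot be read from the data directly. Given that a change at this position moved the number modestly in compound 1 versus compound 3, a step of similar or smaller size in either direction is the most that can be anticipated.

The estimate for compound 4 is 200 nM, with a range from 80 nM to 500 nM, which amounts to an expected step of a 1.6-fold higher number from compound 3 to compound 4 (0.19 log units; within the scatter).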

Compound 4, half-maximal effective concentration: 183 nM
Estimate against measurement, compound 4: 1.1-fold (0.04 log units) above; low and high end bracket the measured number.
By their numbers in this assay, from the lowest: compounds 2, 3, 4 and 1 (each within the scatter of the next, the first and the last beyond it).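

In this assay, cyano in place of methyl on the aromatic carbon gives a step that stays within the scatter (a 1.4-fold higher number from compound 3 to compound 4 (0.15 log units; within the scatter)), even though the entering group adds one heavy atom and one hydrogen-bond acceptor by count. Going by these compounds alone, the other two new steps also stay within the scatter, both the one from the 4-methylphenyl compound (a 1.6-fold higher number from compound 2 to compound 4 (0.22 log units; within the scatter)) and the exchange of chloro for cyano (a 1.6-fold lower number from compound 1 to compound 4 (0.21 log units; within the scatter)), so compound 4 cannot be separated from any of the other three, whereas the exchange of chloro for methyl (a 2.3-fold lower number from compound 1 to compound 3 (0.37 log units; beyond the scatter)) lies beyond the scatter. No measurement shown here bears on why these steps are as small as they are.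

The compounds shown leave open whether any group on this carbon can move the number well beyond the range seen so far, for instance an amine, a carboxylic acid or a methoxy group. Within the data shown here, they also leave open whether cyano would behave the same way as a 4-cyanophenyl group, since methyl is the only group seen in both places on the ring.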